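Stripping the substituents from a weakly active amide

This account rests on a few compounds, and the source may have more. Where it says the series, first, only, none or still open, it means among the compounds named here.

In a functional assay on HOP-62 cells (Homo sapiens) for inhibition, read by sulforhodamine B assay, with a stated time of 48 h (on this read-out higher numbers stand for weaker inhibition of growth and lower numbers for stronger inhibition of growth), compound 1 (`COc1cc(-c2nn(-c3cccc(NC(=O)c4cccc(C(F)(F)F)c4)c3)cc2-c2ccncc2)ccc1Cl`) reports > 50000 nM as a limit of the assay. Compound 3 (`COc1cc(-c2nn(-c3cccc(NC(=O)c4ccc(Cl)c(C(F)(F)F)c4)c3)cc2-c2ccncc2)ccc1Cl`) likewise gives only a limit, > 32500 nM in this assay and no exact number. Compound 2 (`COc1cc(-c2nn(-c3cccc(NC(=O)Nc4ccc(Cl)c(Cl)c4)c3)cc2-c2ccncc2)ccc1Cl`), with (3,4-dichlorophenyl)amino on the carbonyl carbon, gives 4900 nM as a true number. Compound 4 (`COc1cc(-c2nn(-c3cccc(NC(=O)c4ccccc4)c3)cc2-c2ccncc2)ccc1Cl`) has phenyl in place of 4-chloro-3-(trifluoromethyl)phenyl on a carbonyl carbon. The nearest measured change is a step that the two limits leave unreadable from compound 1 to compound 3 and offers no size. Clear steps, an at least 10-fold lower number from compound 1 to compound 2 (1.00 log units; beyond the scatter) and an at least 6.6-fold higher number from compound 2 to compound 3 (0.82 log units; beyond the scatter) in turn, involve the (3,4-dichlorophenyl)amino group, which compound 4 lacks. The expected change is therefore none beyond the scatter, a step that the limit leaves unreadable from compound 3 to compound 4 in this assay as estimated. For compound 4 the estimate is 40000 nM with an expected range of 15000 nM to 100000 nM here.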

Compound 4, concentration for total growth inhibition: > 100000 nM
Compound 4: no number, only a limit; the forecaster's own chance of this, stated with the estimate: 65%; at least 2.5-fold (0.39 log units) between middle value and limit.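

Even with phenyl alone on the carbonyl carbon, compound 4 reaches only a limit of the assay, so stripping the substituents gives no measurable growth inhibition. Putting phenyl in place of (3,4-dichlorophenyl)amino gives an at least 20-fold higher number from compound 2 to compound 4 (1.30 log units; beyond the scatter), which leaves compound 2 as the only one of the four with a true number. The steps among compound 1, compound 3 and compound 4 cannot be read.

Still open, from the compounds shown here alone, is how a urea carrying plain phenyl would behave, which would separate the urea link from the two chloro groups. Also open, going by these compounds, is whether an amine or a carboxylic acid on the phenyl ring of the amide would give a true number.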